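Swapping the Amide Substituent of Compound 2

The source may report more compounds than this note shows. Statements on the series, on what has been measured and on what is new or still open speak of the compounds shown alone.

Measured compounds in a functional assay (QGY7701 cells, Homo sapiens) for inhibition, read by MTT assay, with a stated time of 48 h; a lower number here means a stronger inhibitor, a higher number a weaker inhibitor:
compound 1 `Cc1ccccc1NC(=O)/C=C/c1coc2cc(O)ccc2c1=O` gives 9320 nM
compound 2 `COc1ccc(CNC(=O)/C=C/c2coc3cc(OC)ccc3c2=O)cc1` gives 15700 nM
compound 3 `COc1ccc2c(=O)c(/C=C/C(=O)Nc3ccccc3C)coc2c1` gives 22500 nM

Compound 2 holds the second highest of the three numbers, and its gaps to compound 3 and to compound 1 both fall within the scatter. Compound 4 `COc1ccc2c(=O)c(/C=C/C(=O)Nc3ccc(F)cc3)coc2c1` differs from it in one place: 4-fluorophenyl in place of 4-methoxybenzyl on an amide-type nitrogen. Going by the values given here, the one measured step that touches this position is a 1.4-fold higher number from compound 2 to compound 3 (0.16 log units; within the scatter), which also exchanges the 4-methoxybenzyl group for an aromatic ring set directly on the amide-type nitrogen. The step of a 2.4-fold higher number from compound 1 to compound 3 (0.38 log units; beyond the scatter) concerns the oxygen on the aromatic ring and does not bear here. Compound 4 is therefore expected to show no step beyond the scatter, about a 1.0-fold higher number from compound 2 to compound 4 (0.01 log units; within the scatter). The estimated value of compound 4 is 16000 nM, within 7000 nM to 36000 nM.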

Compound 4, half-maximal inhibitory concentration: > 100000 nM
Compound 4: only a limit was reported; the forecaster's own chance of this, stated with the estimate: 10%; middle value at least 6.2-fold (0.79 log units) away from the limit.
By their numbers in this assay, from the lowest: compounds 1, 2 and 3 (each within the scatter of the next, the first and the last beyond it). At a limit, above all of these: compound 4.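

In this assay compound 4 gives only a limit, not a number: the limit of > 100000 nM in this assay, at which 1 of the 4 values shown sits. The amide-type nitrogen had shown no step beyond the scatter when 2-methylphenyl replaced 4-methoxybenzyl, but 4-fluorophenyl there gives an at least 6.3-fold higher number from compound 2 to compound 4 (0.80 log units; beyond the scatter). Exchanging 2-methylphenyl for 4-fluorophenyl gives an at least 4.4-fold higher number from compound 3 to compound 4 (0.64 log units; beyond the scatter), so an aromatic ring set directly on this nitrogen does not by itself fix the outcome. The compounds shown leave open whether the step follows the fluorine or the missing methyl. A plain phenyl or a 4-aminophenyl on this nitrogen would bear on that question.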